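A few compounds are considered here, and "the series" means these few. Any claim that something is new, unique, unknown or untested is made for them only; others in the source may bear on it.

In an in vivo ADME assay on the whole organism (Rattus norvegicus) for pharmacokinetics (on this read-out lower numbers stand for lower oral bioavailability and higher numbers for higher oral bioavailability), compound 1 `CC1(C)Oc2ccc(C#N)cc2[C@@H](/N=C(\NC#N)Nc2ccccc2)[C@@H]1O` gives 70% and compound 2 `CC1(C)Oc2ccc(C#N)cc2[C@@H](/N=C(\NC#N)Nc2ccc(Cl)cc2)[C@@H]1O` gives 61%. Going by the values given here, these are the only two numbers so far, and they lie within the usual scatter of each other, so compound 2 cannot be ranked against compound 1. Compound 3 `CC1(C)Oc2ccc(C#N)cc2[C@@H](/N=C(\NC#N)Nc2ccc(F)cc2)[C@@H]1O` has not yet been measured. Its structure departs from that of compound 2 by one swap: fluoro in place of chloro on an aromatic carbon. This puts fluoro in place of chloro on an aromatic carbon, para to a large group. Among the compounds with values here, only one measured step bears on this swap: a number 9 percentage points lower from compound 1 to compound 2 (within the scatter), with chloro in place of hydrogen on an aromatic carbon. That step stays within the scatter, so no shift beyond the scatter is expected in this assay. The expected change is a number 4 percentage points higher from compound 2 to compound 3 (within the scatter). For compound 3 the estimated value is 65%, with an expected range from 50% to 80%.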

Compound 3, oral bioavailability: 64%
For compound 3 the middle estimate is 1 percentage points above the measured one; measured number inside the range.
By their numbers in this assay, from the lowest: compounds 2, 3 and 1 (each within the scatter of the next).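

In this assay, fluoro in place of chloro on the aromatic carbon para to a large group gives a number 3 percentage points higher from compound 2 to compound 3 (within the scatter) and, set against the unsubstituted ring, fluoro in place of hydrogen gives a number 6 percentage points lower from compound 1 to compound 3 (within the scatter) for this same carbon. Compound 1 and compound 2 alone covered only one halogen, whereas two different halogens can now be seen to stay within the scatter of hydrogen and of each other. No measurement shown here gives a reason for these numbers.

Going by these compounds alone, still open is whether a group of another kind on this carbon, such as an amine, a carboxylic acid or a longer chain, would produce a step beyond the scatter in this assay for the first time. The compounds shown also leave open whether fluoro or chloro on other carbons of this ring would behave in the same way.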